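The compounds below may be only part of what the source reports. "The series", "measured", "known", "first", "only" and "open" are said of these compounds alone.

Measured so far:
- compound 1 `O=C(Nc1cccc(-c2nc(-c3ccc(NC(=O)c4cccnc4)cc3Cl)no2)c1)Nc1cccc(C(F)(F)F)c1`: 1900 nM
- compound 2 `O=C(Nc1cccc(-c2nc(-c3ccc(NC(=O)c4cccnc4)cc3Cl)no2)c1)Nc1ccc(Cl)c(C(F)(F)F)c1`: 1900 nM
- compound 3 `COc1ccc(NC(=O)Nc2cccc(-c3nc(-c4ccc(NC(=O)c5cccnc5)cc4Cl)no3)c2)cc1C(F)(F)F`: 1700 nM

In a functional assay on MDA-MB-231 cells (Homo sapiens) for antiproliferative activity, read by MTT assay, with a stated time of 72 h (on this read-out higher numbers stand for weaker inhibition and lower numbers for stronger inhibition), the three numbers sit together. Going from compound 1 to compound 3 gives a 1.1-fold lower number from compound 1 to compound 3 (0.05 log units; within the scatter), from compound 2 to compound 3 a 1.1-fold lower number from compound 2 to compound 3 (0.05 log units; within the scatter), and from compound 1 to compound 2 no change at the digits printed from compound 1 to compound 2 (within the scatter). None of these gaps can be told apart from repeat-measurement noise, so compound 3 stands level with the other two rather than apart from them.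

Compound 4 `NS(=O)(=O)Nc1ccc(NC(=O)Nc2cccc(-c3nc(-c4ccc(NC(=O)c5cccnc5)cc4Cl)no3)c2)cc1` differs from compound 3 by 4-(sulfamoylamino)phenyl in place of 4-methoxy-3-(trifluoromethyl)phenyl on an amide-type nitrogen. The two steps that bear on this, into compound 3 from compound 1 and from compound 2, each swapped one small group on this same ring and produced nothing beyond the scatter. The change to compound 4 is larger: the trifluoromethyl leaves as well, and a sulfamoylamino group enters. Within the data shown here, no measured step removes the trifluoromethyl, so the direction is unknown, and a step of any size within modest bounds is possible. The estimated step from compound 3 to compound 4 is a 1.5-fold higher number from compound 3 to compound 4 (0.17 log units; within the scatter). Compound 4 is therefore expected to give about 2500 nM, with a likely range from 800 nM to 8000 nM.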

Compound 4, half-maximal inhibitory concentration: 8900 nM
For compound 4 the middle estimate is 3.6-fold (0.55 log units) below the measured one; measured number outside the range, above it.
By their numbers in this assay, from the lowest: compounds 3, 1 and 2 (each within the scatter of the next); then compound 4.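

Within this assay, the earlier swaps on this ring stayed within the scatter, but placing 4-(sulfamoylamino)phenyl on the amide-type nitrogen gives a 5.2-fold higher number from compound 3 to compound 4 (0.72 log units; beyond the scatter) and a 4.7-fold higher number from compound 2 to compound 4 (0.67 log units; beyond the scatter) and also a 4.7-fold higher number from compound 1 to compound 4 (0.67 log units; beyond the scatter) in the same direction. This position therefore does respond to a change in the group it carries: all three groups with a trifluoromethyl stand level, while the 4-(sulfamoylamino)phenyl group gives weaker inhibition than each of them. No measurement is available to explain this shift.

The compounds shown leave open whether the step comes from the loss of the trifluoromethyl or the arrival of the sulfamoylamino group. A ring carrying an amine or a carboxylic acid in place of the sulfamoylamino group could show whether other groups give a similar step.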